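Ethyl in Place of Acetyl: Compound 2 to Compound 4

A few compounds are considered here, and "the series" means these few. Any claim that something is new, unique, unknown or untested is made for them only; others in the source may bear on it.

Of the compounds shown here, three have so far been measured in a functional assay on MCF7 cells (Homo sapiens) for cytotoxicity, read by XTT assay, with a stated time of 24 h; a higher number here means a weaker inhibitor, a lower number a stronger inhibitor. Compound 1 `CC(=O)Oc1cc(OC(C)=O)c2c(OC(C)=O)c(C)cc(Cl)c2c1OC(C)=O` gives 57500 nM. Compound 2 `CC(=O)Oc1c(C)cc(Cl)c2c1C(=O)C=CC2=O` gives 18700 nM, and compound 3 `Cc1cc(O)c2c(c1Br)C(=O)C=CC2=O` gives 15500 nM. Compound 2 therefore holds the second highest of the three numbers; its value and that of compound 3 lie within the scatter of each other, while compound 1 stands beyond the scatter above it. Compound 4 `CCOc1c(C)cc(Cl)c2c1C(=O)C=CC2=O` has not yet been measured. It differs from compound 2 in a single place: ethyl in place of acetyl on an oxygen on an aromatic ring. Within the data shown here, no measured pair shows this change, so a step no larger than the scatter is expected in this assay, in no firm direction. Compound 4 is expected to give 20000 nM, within a range from 8000 nM to 50000 nM. The expected step is a 1.1-fold higher number from compound 2 to compound 4 (0.03 log units; within the scatter).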

Compound 4, half-maximal inhibitory concentration: 32200 nM
For compound 4 the middle estimate is 1.6-fold (0.21 log units) below the measured one; low and high end bracket the measured number.
By their numbers in this assay, from the lowest: compounds 3, 2, 4 and 1 (each within the scatter of the next, the first and the last beyond it).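

In this assay, the first pair differing in one place gives a 1.7-fold higher number from compound 2 to compound 4 (0.24 log units; within the scatter) with ethyl in place of acetyl, so at this oxygen on an aromatic ring the change from acetoxy to ethoxy stays inside the scatter. Losing the acetyl and its hydrogen-bond acceptor thus produces no step beyond the scatter in this pair. Nothing available explains this step. On these data alone, whether a longer chain such as butyl, or a benzyl group, on this oxygen would give a step beyond the scatter stays open. A single pair also cannot show whether the same change would read alike on another core.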